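From 2-nitrophenyl to 4-nitrophenyl in a cytotoxic series

This account rests on a few compounds, and the source may have more. Where it says the series, first, only, none or still open, it means among the compounds named here.

Measured in a functional assay on HL-60 cells (Homo sapiens) for cytotoxicity, with a stated time of 24 h; on this read-out lower numbers stand for higher toxicity in this test and higher numbers for lower toxicity in this test:
- compound 1 `COc1cc(/C=C2\CCC/C(=C\c3ccccc3[N+](=O)[O-])C2=O)cc(OC)c1OC`: 3000 nM
- compound 2 `COc1ccc(/C=C2\CCC/C(=C\c3ccc([N+](=O)[O-])cc3)C2=O)cc1`: > 400000 nM

Going by the values given here, compound 1 holds the only actual number so far, 3000 nM. For compound 2, > 400000 nM is a limit of the assay and not a number.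

Compound 3 `COc1cc(/C=C2\CCC/C(=C\c3ccc([N+](=O)[O-])cc3)C2=O)cc(OC)c1OC` is still unmeasured. Its change from compound 1 is 4-nitrophenyl in place of 2-nitrophenyl on a double-bonded chain carbon bound to a double-bonded ring carbon. Among the compounds with values here, no measured step isolates this change. Compound 2 also carries 4-nitrophenyl and reaches only the limit of > 400000 nM, so a moderate move toward lower toxicity in this assay is expected. The expected move is a 2.0-fold higher number from compound 1 to compound 3 (0.30 log units; within the scatter). The estimated value for compound 3 is 6000 nM, with an expected range of 1200 nM to 40000 nM.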

Compound 3, half-maximal cytotoxic concentration: 1100 nM
Beside the measured number, compound 3's estimate is 5.5-fold (0.74 log units) above it; the whole stated range lies above it.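

At this place, on a double-bonded chain carbon bound to a double-bonded ring carbon, 4-nitrophenyl does not lower toxicity in this assay: the change gives a 2.7-fold lower number from compound 1 to compound 3 (0.44 log units; beyond the scatter), a modest move in the opposite direction. Compound 3 thus shows that 4-nitrophenyl can sit in a compound with a measurable value. Compound 2, which also carries 4-nitrophenyl, stands only at a limit of the assay, > 400000 nM, and not at a number.

Going by these compounds, whether an amine or a carboxylic acid in place of the nitro group would keep this value remains open. The compounds shown also leave open how the methoxy groups on the other aromatic ring contribute.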